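The source may hold more compounds than are shown below. What is called first, only, known or untested is meant among the compounds shown, and "the series" means these compounds.

Of the compounds shown here, three built on the same core have been measured in a functional assay on HeLa cells (Homo sapiens) for antiproliferative activity, read by cell counting, with a stated time of 3 days; on this read-out higher numbers stand for weaker inhibition and lower numbers for stronger inhibition. Compound 1 `CC(Nc1ccccc1Oc1ccc(Cl)cc1)=C1C(=O)CC(c2ccccc2)CC1=O` gives 500 nM, compound 2 `CC(Nc1ccccc1Oc1ccccc1)=C1C(=O)CC(c2ccccc2)CC1=O` gives 79 nM, and compound 3 `COc1cc(Oc2ccccc2NC(C)=C2C(=O)CC(c3ccccc3)CC2=O)ccc1N` gives 33 nM. Compound 3 thus has the lowest number of the three, with compound 2 nearest to it and compound 1 furthest away. The unmeasured compound 4 `CC(Nc1ccccc1Oc1cccc(F)c1)=C1C(=O)CC(c2ccccc2)CC1=O` differs from compound 3 in one place: 3-fluorophenyl in place of 4-amino-3-methoxyphenyl on an oxygen on an aromatic ring. Among the measured compounds shown here, two measured steps bear on this. The step of a 2.4-fold lower number from compound 2 to compound 3 (0.38 log units; beyond the scatter) shows how much the 4-amino-3-methoxyphenyl group lowered the number compared with a plain phenyl group, so removing it should cost roughly that much. The step of a 6.3-fold lower number from compound 1 to compound 2 (0.80 log units; beyond the scatter) shows that a chloro group on that ring raised the number further. Compound 4 carries a fluoro group instead of a chloro group, so its number is expected to land between those two cases, a step of a 3.6-fold higher number from compound 3 to compound 4 (0.56 log units; beyond the scatter). Compound 4 is therefore estimated at 120 nM, within a range of 40 nM to 400 nM.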

Compound 4, half-maximal inhibitory concentration: 550 nM
The estimate for compound 4 lay 4.6-fold (0.66 log units) below the measured number; measured number outside the range, above it.
By their numbers in this assay, from the lowest: compound 3; then compound 2; then compounds 1 and 4 (each within the scatter of the next).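

The change from 4-amino-3-methoxyphenyl to 3-fluorophenyl in this assay gives a 17-fold higher number from compound 3 to compound 4 (1.22 log units; beyond the scatter) and shows how widely the number can move with this one group on the oxygen. Adding a single fluoro group to the plain phenyl ring gives a 7.0-fold higher number from compound 2 to compound 4 (0.84 log units; beyond the scatter), while 3-fluorophenyl in place of 4-chlorophenyl gives a 1.1-fold higher number from compound 1 to compound 4 (0.04 log units; within the scatter), so these two halogen-bearing compounds cannot be told apart here, even though their halogen and its place on the ring both differ. Nothing measured here explains these differences. The compounds shown leave open which part of the 4-amino-3-methoxyphenyl group goes with its low number, the amine or the methoxy group. They also leave open how a ring carrying a nitrile or a carboxylic acid would compare.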